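A few compounds are considered here, and "the series" means these few. Any claim that something is new, unique, unknown or untested is made for them only; others in the source may bear on it.

Compound 1, `Cc1ccc(-c2nc(=O)o[nH]2)c(-c2ccc([C@@H](C)N(CC3CC3)c3nc(C(=O)NS(=O)(=O)C4CC4)c(C4CC4)s3)cc2)c1`: 2210 nM
Compound 2, `CONC(=O)c1ccc(Cl)cc1-c1ccc([C@@H](C)N(CC2CC2)c2nc(C(=O)NS(=O)(=O)C3CC3)c(C3CC3)s2)cc1`: 769 nM

Both compounds were examined in an ADME assay on the whole organism (Macaca fascicularis) for pharmacokinetics, at a dose of 0.3 mg/kg by the oral route; on this read-out lower numbers stand for lower exposure and higher numbers for higher exposure at the dose given. In this assay compound 1 gives 2210 nM, and compound 2 gives 769 nM. Compound 2 thus stands at the lower of the two numbers, and the gap between the two values lies beyond the usual scatter of this assay, with compound 1 the higher of the pair.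

Compound 3, `CNC(=O)c1ccc(Cl)cc1-c1ccc([C@@H](C)N(CC2CC2)c2nc(C(=O)NS(=O)(=O)C3CC3)c(C3CC3)s2)cc1`, has not yet been measured. It differs from compound 2 in a single place: methyl in place of methoxy on an amide-type nitrogen. Within the data shown here, no step between two measured compounds carries this same change, so there is no direct precedent here for how it moves the read-out. The two measured compounds differ from each other at several places at once and so tell nothing about this particular exchange. The expected step, a 1.0-fold higher number from compound 2 to compound 3 (0.02 log units; within the scatter), is estimated to lie within the usual scatter rather than beyond it, with no clear direction. On this basis compound 3 is estimated at 800 nM in this assay, with a range from 300 nM to 2100 nM.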

Compound 3, maximal plasma concentration: 1460 nM
For compound 3 the middle estimate is 1.8-fold (0.26 log units) below the measured one, within the range that was stated.
By their numbers in this assay, from the lowest: compounds 2, 3 and 1 (each within the scatter of the next, the first and the last beyond it).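

In this assay, among these compounds, the exchange of methoxy for methyl on the amide-type nitrogen gives a 1.9-fold higher number from compound 2 to compound 3 (0.28 log units; within the scatter) and so provides the first reading of this change. At this position, methylcarbamoyl can therefore stand in place of methoxycarbamoyl, with the oxygen and its hydrogen-bond acceptor gone, and the read-out does not separate the two groups beyond the usual scatter. This single pair gives no sign that an oxygen on this nitrogen is required for the exposure seen at this dose, though it cannot show whether that holds on any other core. No measurement at hand bears on why the two compounds read as they do.

The compounds shown leave open how the read-out would respond to a larger change at this place, such as a primary carboxamide, an ethyl group on the same nitrogen, or a carboxylic acid in place of the whole methylcarbamoyl group. They also leave open whether the 5-chloro substituent on the same phenyl ring has any bearing on this result.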